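Bromo for Methyl on the Aryl Ketone of Compound 3

The source may hold more compounds than are shown below. What is called first, only, known or untested is meant among the compounds shown, and "the series" means these compounds.

The series rests on a shared core, seen in compound 1 `COc1cc(-c2nnc3n2NC(c2cccs2)C(C(=O)c2ccc(C)cc2)S3)cc(OC)c1OC`, compound 2 `COc1cc(-c2nnc3n2NC(c2cccs2)C(C(=O)c2ccc(F)cc2)S3)cc(OC)c1OC` and compound 3 `COc1cc(-c2nnc3n2NC(c2ccco2)C(C(=O)c2ccc(C)cc2)S3)cc(OC)c1OC`. In a functional assay on HepG2 cells (Homo sapiens) for cytotoxicity, read by MTT assay, with a stated time of 48 h (a higher number here means a weaker inhibitor, a lower number a stronger inhibitor), compound 1 gives 3700 nM, compound 2 gives 54200 nM, and compound 3 gives 17400 nM, which places compound 3 second highest of the three numbers shown. The unmeasured compound 4 `COc1cc(-c2nnc3n2NC(c2ccco2)C(C(=O)c2ccc(Br)cc2)S3)cc(OC)c1OC` differs from compound 3 by bromo in place of methyl on an aromatic carbon, on an aromatic carbon of a six-membered aromatic ring of carbon only, para to a large group. The closest guide is the step of a 15-fold higher number from compound 1 to compound 2 (1.17 log units; beyond the scatter), where a halogen replaced the same methyl; the other step, a 4.7-fold higher number from compound 1 to compound 3 (0.67 log units; beyond the scatter), touches a different part of the molecule. For the measured compounds named here, no measured pair shows bromo itself, so the expectation is uncertain, but a higher number is expected for compound 4, with an estimated step of a 2.9-fold higher number from compound 3 to compound 4 (0.46 log units; beyond the scatter). Compound 4 is therefore estimated at 50000 nM in this assay, expected to lie between 15000 nM and 180000 nM.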

Compound 4, half-maximal inhibitory concentration: > 100000 nM
Compound 4: a limit, no number; the forecaster's own chance of this, stated with the estimate: 10%; middle value at least 2.0-fold (0.30 log units) from the limit.
By their numbers in this assay, from the lowest: compound 1; then compound 3; then compound 2. At a limit, above all of these: compound 4.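

Compound 4 stands at a limit of this assay, not at a number: the limit of > 100000 nM in this assay, at which 1 of the 4 values shown sits. Even so, the step can be read as a minimum, an at least 5.7-fold higher number from compound 3 to compound 4 (0.75 log units; beyond the scatter), and it shows that the rise seen with fluoro, a 15-fold higher number from compound 1 to compound 2 (1.17 log units; beyond the scatter), is not confined to that halogen or to the thiophen-2-yl compounds, as it also appears with bromo in a furan-2-yl compound. For the compounds shown here, in both pairs that differ at this aromatic carbon, the methyl compound has the lower number, with no pair going against this.

The limit leaves open how the size of the bromo step compares with that of the fluoro step. Also open, going by these compounds, is whether an amine, a carboxylic acid or a longer chain at this position would keep a number as low as methyl does.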